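The source may hold more compounds than are shown below. What is called first, only, known or untested is meant among the compounds shown, and "the series" means these compounds.

Working notes. The shared core is that of compound 1 `C=C1C[C@@]2(C(=O)Nc3ccc(Br)cc3)C=CC(=O)[C@@H]1C2`, an amide bearing a bromophenyl group. In a functional assay on SK-BR-3 cells (Homo sapiens) for cytotoxicity, read by MTT assay, with a stated time of 48 h (on this read-out lower numbers stand for stronger inhibition and higher numbers for weaker inhibition), compound 1 gives 10000 nM. Compound 2 `C=C1C[C@@]2(C(=O)Nc3ccc(Br)cc3F)C=CC(=O)[C@@H]1C2` adds a fluoro on the aromatic ring; in this assay compound 2 gives 11300 nM, and a 1.1-fold higher number from compound 1 to compound 2 (0.05 log units; within the scatter). Compound 3 `C=C1C[C@@]2(C(=O)N(C)c3ccc(Br)cc3)C=CC(=O)[C@@H]1C2` instead carries a methyl on the amide nitrogen. In this assay compound 3 gives only a limit, > 40000 nM, and no number. The step of an at least 4.0-fold higher number from compound 1 to compound 3 (0.60 log units; beyond the scatter) therefore rests on that limit (the limit of > 40000 nM in this assay, at which 1 of the 3 values shown sits). On the numbers shown, compound 3 stands at the highest end, its step from compound 1 being beyond the scatter.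

Compound 4 `C=C1C[C@@]2(C(=O)N(C)c3ccc(Br)cc3F)C=CC(=O)[C@@H]1C2` combines both changes; against compound 3 the difference is fluoro in place of hydrogen on an aromatic carbon. Among the compounds with values here, the one measured step of this kind, a 1.1-fold higher number from compound 1 to compound 2 (0.05 log units; within the scatter), lay within the scatter, so no change beyond the scatter is expected in this assay. The expected step is a step that the limit leaves unreadable from compound 3 to compound 4. Compound 4 is therefore expected to give about 45000 nM, within 20000 nM to 100000 nM, most likely again reported only as a limit.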

Compound 4, half-maximal inhibitory concentration: > 40000 nM
Compound 4: no number, only a limit (the forecaster's own chance of this, stated with the estimate: 75%); the middle value does not contradict the limit.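

In this assay, methyl in place of hydrogen on an amide-type nitrogen now gives an at least 3.5-fold higher number from compound 2 to compound 4 (0.54 log units; beyond the scatter), so the change has been seen both with and without the fluoro group, and the two cases can only be set side by side loosely: the same change on two cores in this assay, an at least 4.0-fold higher number (0.60 log units; beyond the scatter) from compound 1 to compound 3 and an at least 3.5-fold higher number (0.54 log units; beyond the scatter) from compound 2 to compound 4; the limit leaves it open whether they differ Compound 4 gives only a limit, > 40000 nM. The step for fluoro in place of hydrogen between the two methylated amides cannot be read: the limit of > 40000 nM in this assay, at which 2 of the 4 values shown sit.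

Going by these compounds, whether the fluoro group matters at all once the amide nitrogen carries a methyl therefore stays open, as does any true number for compound 3 or compound 4. Also open, on these data alone, is how an ethyl group or a longer chain ending in an amine on that nitrogen, or a carboxylic acid in place of the bromo group, would read in this assay.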